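The source may report more compounds than this note shows. Statements on the series, on what has been measured and on what is new or still open speak of the compounds shown alone.

In a functional assay on SiHa cells (Homo sapiens) for inhibition (a lower number here means a stronger inhibitor, a higher number a weaker inhibitor), compound 1 `COc1cc(/C=C/C(=O)c2cccc(NC(=O)C(C)C)c2)ccc1O` gives 5.96 ug/mL, and compound 2 `COC(=O)C(=O)Nc1cccc(C(=O)/C=C/c2ccc(O)c(OC)c2)c1` gives 7.71 ug/mL. Compound 3 `CCOC(=O)C(=O)Nc1cccc(C(=O)/C=C/c2ccc(O)c(OC)c2)c1` does not return a number: in this assay compound 3 reaches only the limit > 50 ug/mL. As far as these compounds go, the two steps that end at compound 3, an at least 8.3-fold higher number from compound 1 to compound 3 (0.92 log units; beyond the scatter) and an at least 6.4-fold higher number from compound 2 to compound 3 (0.81 log units; beyond the scatter), are both read against that limit (the limit of > 50 ug/mL in this assay, at which 1 of the 3 values shown sits), so their true size is unknown beyond being at least modest. Compound 4 `COc1cc(/C=C/C(=O)c2cccc(NC(=O)c3c(Cl)cccc3Cl)c2)ccc1O` differs from compound 3 at the same place: 2,6-dichlorophenyl in place of ethoxycarbonyl on a carbonyl carbon. Among the measured compounds shown here, no measured step makes this change; the nearest comparison is a 1.3-fold higher number from compound 1 to compound 2 (0.11 log units; within the scatter), which shows that isopropyl and methoxycarbonyl on that carbonyl carbon give numbers within the scatter of each other, while ethoxycarbonyl alone pushes the number past the limit. A 2,6-dichlorophenyl is unlike any of the three. Compound 4 is therefore expected to fall back below the limit, with an estimated step of an at least 5.0-fold lower number from compound 3 to compound 4 (0.69 log units; beyond the scatter). Compound 4 is estimated at 10 ug/mL in this assay, with a range from 3 ug/mL to 40 ug/mL.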

Compound 4, half-maximal inhibitory concentration: 3.56 ug/mL
The estimate for compound 4 lay 2.8-fold (0.45 log units) above the measured number; the range from low to high includes it.
By their numbers in this assay, from the lowest: compounds 4, 1 and 2 (each within the scatter of the next, the first and the last beyond it). At a limit, above all of these: compound 3.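

Among the compounds shown here, with a six-membered aromatic ring of carbon only on the carbonyl carbon bound to the amide-type nitrogen, compound 4 shows that this position is not limited to the open-chain groups of the earlier compounds in this assay. Measured against isopropyl, 2,6-dichlorophenyl gives a 1.7-fold lower number from compound 1 to compound 4 (0.22 log units; within the scatter), and measured against methoxycarbonyl it gives a 2.2-fold lower number from compound 2 to compound 4 (0.34 log units; beyond the scatter). Against ethoxycarbonyl the change gives an at least 14-fold lower number from compound 3 to compound 4 (1.14 log units; beyond the scatter), a step whose full size stays unknown, as it rests on a limit of the assay: the limit of > 50 ug/mL in this assay, at which 1 of the 4 values shown sits.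

A plain phenyl at this carbonyl carbon would show how much of the result for compound 4 belongs to the ring and how much to the chlorine atoms. As far as these compounds go, whether the abrupt difference between methoxycarbonyl and ethoxycarbonyl continues with a longer chain, such as propoxycarbonyl, also remains open.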